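This account rests on a few compounds, and the source may have more. Where it says the series, first, only, none or still open, it means among the compounds named here.

In a functional assay on A549 cells (Homo sapiens) for inhibition (a lower number here means a stronger inhibitor, a higher number a weaker inhibitor), compound 1 `O=C(CC(CC(=O)NC1Cc2ccccc2C1)c1ccc(Cl)cc1)NCCN1CCCCC1` gives 28000 nM and compound 2 `CCN(CC)CCNC(=O)CC(CC(=O)NC1Cc2ccccc2C1)c1ccc(Cl)cc1` gives 48600 nM, so compound 1 has no measured neighbour beyond the scatter. For the measured compounds named here, the only measured step is a 1.7-fold higher number from compound 1 to compound 2 (0.24 log units; within the scatter), and it concerns the amine end of the chain, not the aromatic ring. Compound 3 `O=C(CC(CC(=O)NC1Cc2ccccc2C1)c1ccccc1)NCCN1CCCCC1` carries hydrogen in place of chloro on an aromatic carbon. Going by the values given here, no measured step covers this change, so the data give it no size. A small move to a higher number in this assay is expected, possibly none beyond the scatter. The expected step is a 1.5-fold higher number from compound 1 to compound 3 (0.18 log units; within the scatter). For compound 3 the estimated value is 42000 nM, within an expected range of 17000 nM to 100000 nM.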

Compound 3, half-maximal inhibitory concentration: > 100000 nM
Compound 3 was reported as a limit; the forecaster's own chance of this, stated with the estimate: 20%; at least 2.3-fold (0.37 log units) between middle value and limit.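

In this assay, for the compounds shown here, hydrogen in place of chloro on an aromatic carbon gives an at least 3.5-fold higher number from compound 1 to compound 3 (0.55 log units; beyond the scatter), the first step beyond the scatter, whereas the change at the amine end, a 1.7-fold higher number from compound 1 to compound 2 (0.24 log units; within the scatter), stays within it. The chloro of the 4-chlorophenyl group therefore contributes measurably to the activity of compound 1. The value of compound 3, > 100000 nM, is a limit, so the true size of the step remains unknown: the limit of > 100000 nM in this assay, at which 1 of the 3 values shown sits.

Going by these compounds, whether chloro itself is needed or other groups, such as fluoro, methyl or methoxy, would serve on the same aromatic carbon stays open. Also open, on these data alone, is whether the step holds with diethylamino at the chain end.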